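The source may report more compounds than this note shows. Statements on the series, on what has been measured and on what is new or still open speak of the compounds shown alone.

Series notes. Compound 2 `C#Cc1cn([C@@H]2O[C@H](CO)[C@@H](O)[C@H]2O)c2ncnc(N(C)C)c12` carries ethynyl on the core; in a functional assay on HCT-116 cells (Homo sapiens), read by MTT assay, with a stated time of 72 h (on this read-out higher numbers stand for weaker inhibition and lower numbers for stronger inhibition), compound 2 gives 180 nM. Compound 1 `CN(C)c1ncnc2c1c(-c1ccoc1)cn2[C@@H]1O[C@H](CO)[C@@H](O)[C@H]1O` is the furan analogue of compound 2, and in this assay compound 1 reaches only a limit, > 20000 nM. The change furan-3-yl in place of ethynyl on an aromatic carbon therefore gave an at least 110-fold higher number from compound 2 to compound 1 (2.04 log units; beyond the scatter), a large loss. Compound 3 `C#Cc1cn([C@@H]2O[C@H](CO)[C@@H](O)[C@H]2O)c2nc(N)nc(OC)c12` keeps ethynyl on another core; how the two cores differ is not broken down here. In this assay compound 3 also stops at a limit, > 20000 nM. Compound 4 `COc1nc(N)nc2c1c(-c1ccoc1)cn2[C@@H]1O[C@H](CO)[C@@H](O)[C@H]1O` is compound 3 with furan-3-yl in place of ethynyl on an aromatic carbon; the surroundings of the place match word for word, so this is the same change as from compound 2 to compound 1. For compound 4 a step that the limit leaves unreadable from compound 3 to compound 4 is expected, resting on (the limit of > 20000 nM in this assay, at which 2 of the 3 values shown sit), where compound 3 already sits, and on an at least 110-fold higher number from compound 2 to compound 1 (2.04 log units; beyond the scatter). Compound 4 is expected at 60000 nM, most likely reported only as a limit.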

Compound 4, half-maximal inhibitory concentration: > 20000 nM
Compound 4: no number, only a limit; the forecaster's own chance of this, stated with the estimate: 90%; the middle value does not contradict the limit.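

No step can be read from compound 3 to compound 4, since both stop at a limit: the limit of > 20000 nM in this assay, at which 3 of the 4 values shown sit.

From the compounds shown here alone, what furan-3-yl in place of ethynyl does on the core of compound 3 remains open.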